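Taking one methyl off compound 1

This account rests on a few compounds, and the source may have more. Where it says the series, first, only, none or still open, it means among the compounds named here.

In a functional assay on SEM cells (Homo sapiens) for cytotoxicity, read by MTT assay, with a stated time of 72 h (a lower number here means a stronger inhibitor, a higher number a weaker inhibitor), compound 1 (`COC(=O)c1sc2c(C)cccc2c1Nc1cc(OC)c(OC)c(OC)c1`) gives 1630 nM. Compound 3 (`CCOC(=O)c1sc2cccc(C)c2c1Nc1cc(OC)c(OC)c(OC)c1`) gives 1930 nM, a value within the scatter of that of compound 1. Compound 2 (`COC(=O)c1sc2nc(C)ccc2c1Nc1cc(OC)c(OC)c(OC)c1`) reads far lower at 0.5 nM, so compound 1 stands well above it and level with compound 3. Compound 4 (`COC(=O)c1sc2ccccc2c1Nc1cc(OC)c(OC)c(OC)c1`) has hydrogen in place of methyl on an aromatic carbon. For the measured compounds named here, no two measured compounds differ in one place only, so nothing measured isolates this change, and any forecast stays loose. A modest move toward a lower number is expected in this assay, and the estimated step is a 2.3-fold lower number from compound 1 to compound 4 (0.37 log units; beyond the scatter). Compound 4 is expected at 700 nM, with an estimated range of 70 nM to 4000 nM.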

Compound 4, half-maximal inhibitory concentration: 179 nM
The estimate for compound 4 lay 3.9-fold (0.59 log units) above the measured number; measured number inside the range.
By their numbers in this assay, from the lowest: compound 2; then compound 4; then compounds 1 and 3 (each within the scatter of the next).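

For the compounds shown here, putting hydrogen in place of the methyl gives a 9.1-fold lower number from compound 1 to compound 4 (0.96 log units; beyond the scatter) in this assay, and this is the first change in the set that can be read on its own. On the core of compound 1, then, the methyl at this aromatic carbon goes with a weaker result than hydrogen does. Nothing measured here explains the step.

Going by these compounds, whether a fluorine or an amine at this carbon would give a lower or a higher number stays open. So does whether removing a methyl has a similar effect on the core of compound 2 or compound 3.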